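The source may report more compounds than this note shows. Statements on the series, on what has been measured and on what is new or still open speak of the compounds shown alone.

Measured in a functional assay on OVCAR-4 cells (Homo sapiens) for antiproliferative activity, read by WST assay, with a stated time of 3 days; on this read-out higher numbers stand for weaker inhibition and lower numbers for stronger inhibition:
- compound 1 `Nc1cc(=O)[nH]c(=O)n1[C@@H]1O[C@H](CO)[C@@H](O)[C@H]1O`: > 50000 nM
- compound 2 `CNc1cc(=O)[nH]c(=O)n1[C@@H]1O[C@H](CO)[C@@H](O)[C@H]1O`: > 50000 nM
- compound 3 `CN(C)c1cc(=O)[nH]c(=O)n1[C@@H]1O[C@H](CO)[C@@H](O)[C@H]1O`: > 50000 nM

Compound 1 stands at a limit, not a number. For the measured compounds named here, the same holds for compounds 2 and 3, and the series so far offers only (the limit of > 50000 nM in this assay, at which 3 of the 3 values shown sit).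

Compound 4 `Nc1c(F)c(=O)[nH]c(=O)n1[C@@H]1O[C@H](CO)[C@@H](O)[C@H]1O` differs from compound 1 by fluoro in place of hydrogen on an aromatic carbon, ortho to the amino group.

The measured steps all change the amino group, and none has a readable size: a step that the two limits leave unreadable from compound 1 to compound 2, a step that the two limits leave unreadable from compound 1 to compound 3 and a step that the two limits leave unreadable from compound 2 to compound 3. They therefore give no direct guide to the fluoro change.

A modest move towards stronger inhibition is expected, with a further limit reading quite possible: an at least 1.6-fold lower number from compound 1 to compound 4 (0.22 log units; that floor lies within the scatter). The estimate for compound 4 is 30000 nM, with an expected range of 3000 nM to 50000 nM.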

Compound 4, half-maximal inhibitory concentration: 2000 nM
For compound 4 the middle estimate is 15-fold (1.18 log units) above the measured one; measured number below the stated range.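

Fluoro in place of hydrogen on an aromatic carbon, ortho to an amino group, gives an at least 25-fold lower number from compound 1 to compound 4 (1.39 log units; beyond the scatter), so this position responds in this assay, whereas the steps on the amino group cannot be read. Compound 4 alone in the series gives a number rather than a limit, and the other compounds all share that limit: the limit of > 50000 nM in this assay, at which 3 of the 4 values shown sit. Going by these compounds, compound 1 stands at a limit, so the step is a floor and its full size remains unknown.

Open, on these data alone, is whether chloro, methyl or nitrile at this position would give a similar step. Also open, as far as these compounds go, is whether methylamino or dimethylamino in place of amino would keep the gain with fluoro present.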